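A few compounds are considered here, and "the series" means these few. Any claim that something is new, unique, unknown or untested is made for them only; others in the source may bear on it.

Compounds measured so far in an assay on membranes from liver for displacement of a labelled ligand from Glucagon receptor (Mus musculus), read by scintillation counting, with a stated time of 60 min; on this read-out lower numbers stand for stronger inhibition and higher numbers for weaker inhibition:
compound 1 `C[C@H](c1ccc(C(=O)NCCC(=O)O)cc1)N1C(=O)C(c2ccc(F)cc2)=N[C@]12CC[C@@H](C(C)(C)C)CC2`, 2500 nM
compound 2 `CC(C)(C)[C@H]1CC[C@]2(CC1)N=C(c1cccc(C(F)(F)F)c1)C(=O)N2Cc1ccc(C(=O)NCCC(=O)O)cc1`, 10000 nM
compound 3 `CC(C)(C)CC[C@H](c1ccc(C(=O)NCc2nn[nH]n2)cc1)N1C(=O)C(c2cncc(Cl)c2)=N[C@]12CC[C@@H](C(C)(C)C)CC2`, 84 nM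

Compound 1 stands second highest of the three numbers in this assay. Compound 2 gives the higher number, and the gap lies beyond the scatter. Compound 3 gives the lowest number of the set, again beyond the scatter from compound 1; compound 3 differs from compound 1 in several places at once, so no single change can be credited from these two values.

Compound 4 `C[C@H](c1ccc(C(=O)NCCC(=O)O)cc1)N1C(=O)C(c2cccc(Cl)c2F)=N[C@]12CC[C@@H](C(C)(C)C)CC2` is the next compound to be measured in this assay. The change from compound 1 is 3-chloro-2-fluorophenyl in place of 4-fluorophenyl on a carbon with a double bond to nitrogen. Among the compounds with values here, no pair of measured compounds differs in just this one place, so the size of this step is not known from the data. The expectation is a modest move toward a lower number, not firmly beyond the scatter, and the step from compound 1 to compound 4 is estimated as a 2.1-fold lower number from compound 1 to compound 4 (0.32 log units; beyond the scatter). Compound 4 is therefore expected to give about 1200 nM in this assay, within a range of 400 nM to 4000 nM.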

Compound 4, half-maximal inhibitory concentration: 4000 nM
The estimate for compound 4 lay 3.3-fold (0.52 log units) below the measured number; measured number inside the range.
By their numbers in this assay, from the lowest: compound 3; then compounds 1 and 4 (each within the scatter of the next); then compound 2.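

In this assay, within the data shown here, 3-chloro-2-fluorophenyl in place of 4-fluorophenyl on a carbon with a double bond to nitrogen gives the first single-place step (a 1.6-fold higher number from compound 1 to compound 4 (0.20 log units; within the scatter)). With the rest of the core of compound 1 and its side chain held fixed, the two aryl groups cannot be told apart at this position, so adding a chlorine and changing the fluorine placement leaves the read-out within the usual scatter. No measurement bears on why this step is so small.

From the compounds shown here alone, it stays open whether an unsubstituted phenyl, or a phenyl carrying a methoxy group, would give a number outside that scatter at this carbon. The separate contribution of each place in which compound 3 differs from compound 1 also remains unresolved.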